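The source may report more compounds than this note shows. Statements on the series, on what has been measured and on what is new or still open speak of the compounds shown alone.

Three compounds built around a hydrazone link between an iodinated phenol and a benzoyl group have been tested for their effect on liver-derived cells. In a functional assay on HepG2 cells (Homo sapiens) for cytotoxicity, with a stated time of 24 h (on this read-out lower numbers stand for stronger inhibition and higher numbers for weaker inhibition), compound 1 `CC(C)(C)c1ccc(C(=O)N/N=C/c2cc(I)cc(I)c2O)cc1` gives 41600 nM. In the same test compound 2 `O=C(N/N=C/c1cc(I)cc(I)c1O)c1ccc(O)cc1` gives 19200 nM. These two differ in one place only, namely (hydroxy in place of tert-butyl on an aromatic carbon), and that change brought a 2.2-fold lower number from compound 1 to compound 2 (0.34 log units; beyond the scatter). Compound 3 `CC(C)(C)c1ccc(C(=O)N/N=C/c2cc(I)c(O)c(I)c2)cc1` contains the same atoms as compound 1, joined in a different arrangement; the difference between the two cores is not broken down here. In this assay compound 3 gives 45900 nM, which is the highest of the three numbers, though it lies within the usual scatter of compound 1 and beyond it only against compound 2.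

Compound 4 `O=C(N/N=C/c1cc(I)c(O)c(I)c1)c1ccc(O)cc1` has not yet been measured. It relates to compound 3 exactly as compound 2 relates to compound 1: the change is hydroxy in place of tert-butyl on an aromatic carbon, the same kind of change at the same kind of place. Among the measured compounds shown here, with only one earlier example of this change, the expectation rests on that single step, a 2.2-fold lower number from compound 1 to compound 2 (0.34 log units; beyond the scatter), applied to the number for compound 3. Compound 4 is therefore expected to show a 2.2-fold lower number from compound 3 to compound 4 (0.34 log units; beyond the scatter) in this assay. Compound 4 is estimated at 21000 nM in this assay, with a likely range from 10000 nM to 45000 nM.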

Compound 4, half-maximal inhibitory concentration: 110000 nM
Beside the measured number, compound 4's estimate is 5.2-fold (0.72 log units) below it; measured number outside the range, above it.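

On the second core the same swap of tert-butyl for hydroxy brought a 2.4-fold higher number from compound 3 to compound 4 (0.38 log units; beyond the scatter), which means weaker inhibition, not stronger. So in this assay the change did not carry over from one core to the other, and even the direction of the step reversed: the same change on two cores in this assay, a 2.2-fold lower number (0.34 log units; beyond the scatter) from compound 1 to compound 2 and a 2.4-fold higher number (0.38 log units; beyond the scatter) from compound 3 to compound 4, 5.2-fold (0.72 log units) apart, beyond the scatter of two such steps

This shows that, across these four compounds, the result of the swap depends on the core it is made on, even though the two cores hold the same atoms in a different arrangement. It does not show why the two steps part ways, and with a single pair on each core it cannot say which core's behaviour would be the more typical for the series, or whether either step would hold for a different change.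

As far as these compounds go, only tert-butyl and hydroxy are compared here, so it stays open how other groups at this place, such as a methoxy, an amine or a carboxylic acid, would behave on each core. From the compounds shown here alone, it also stays open whether those groups would split between the two cores as hydroxy and tert-butyl do, or give similar numbers on both.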